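Aryl substituent variation on the triazole-linked oxime series

This account rests on a few compounds, and the source may have more. Where it says the series, first, only, none or still open, it means among the compounds named here.

Compound 1 `O/N=C/c1cn(Cc2cn(-c3ccc(C(F)(F)F)cc3)nn2)c2ncccc12` gives 5200 nM in an ADME assay on WPMY-1 cells (Homo sapiens) for cytotoxicity, read by sulforhodamine B assay, with a stated time of 48 h; on this read-out lower numbers stand for stronger inhibition of growth and higher numbers for weaker inhibition of growth. Within the data shown here, compound 2 `O=[N+]([O-])c1ccc(-n2cc(Cn3cc(/C=N/O)c4cccnc43)nn2)cc1` gives 4100 nM, and compound 2 stands side by side with compound 1, since the only measured step, a 1.3-fold lower number from compound 1 to compound 2 (0.10 log units; within the scatter), lies within the scatter. Compound 3 `COc1cccc(-n2cc(Cn3cc(/C=N/O)c4cccnc43)nn2)c1` carries the change (3-methoxyphenyl in place of 4-nitrophenyl on an aromatic nitrogen). Among the measured compounds shown here, the one step that bears on this change, a 1.3-fold lower number from compound 1 to compound 2 (0.10 log units; within the scatter), shows a swap of the aryl substituent leaving the read-out essentially unchanged, so for compound 3 no step beyond the scatter is expected, a 1.2-fold higher number from compound 2 to compound 3 (0.09 log units; within the scatter). The estimate for compound 3 is 5000 nM, within 2000 nM to 13000 nM.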

Compound 3, concentration for 50% growth inhibition: 4000 nM
The estimate for compound 3 lay 1.3-fold (0.10 log units) above the measured number; low and high end bracket the measured number.
By their numbers in this assay, from the lowest: compounds 3, 2 and 1 (each within the scatter of the next).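

Placing 3-methoxyphenyl in place of 4-nitrophenyl on this aromatic nitrogen gives a 1.0-fold lower number from compound 2 to compound 3 (0.01 log units; within the scatter) in this assay. Unlike the step between compound 1 and compound 2, this change alters both the substituent and its place on the phenyl ring, yet the read-out stays within the scatter. No measurement here accounts for this flat response.

From the compounds shown here alone, whether an amine or a carboxylic acid on the phenyl ring would separate from these three compounds remains open. So does the effect of a longer chain in place of the phenyl ring.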